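This account rests on a few compounds, and the source may have more. Where it says the series, first, only, none or still open, it means among the compounds named here.

Compound 3 (`N#Cc1ccc(N2CCN(C(=S)SCc3ccc(C(=O)Nc4ccccc4N)cc3)CC2)cc1`) is tested in a functional assay on MGC-803 cells (Homo sapiens) for antiproliferative activity, read by CCK-8 assay, with a stated time of 72 h, tested at 8 uM (on this read-out higher numbers stand for a stronger effect at the one concentration tested and lower numbers for a weaker effect), where it gives 37.6%. Of the three numbers measured, this is the second highest: compound 1 (`Nc1ccccc1NC(=O)c1ccc(CSC(=S)N2CCN(c3cccnc3)CC2)cc1`) gives 76.9% in this assay, and compound 2 (`COc1ccc(N2CCN(C(=S)SCc3ccc(C(=O)Nc4ccccc4N)cc3)CC2)cc1`) gives 22.9%. Compound 2 is the nearest neighbour of compound 3, since a number 14.7 percentage points higher from compound 2 to compound 3 (beyond the scatter); compound 1 is the furthest, since a number 39.3 percentage points lower from compound 1 to compound 3 (beyond the scatter).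

Compound 4 (`Nc1ccccc1NC(=O)c1ccc(CSC(=S)N2CCN(c3ccccc3F)CC2)cc1`) has not yet been measured. It differs from compound 3 in one place: 2-fluorophenyl in place of 4-cyanophenyl on an amine nitrogen in a ring.

Within the data shown here, three measured steps bear on this change, all of them at the same ring nitrogen. Replacing pyridin-3-yl with 4-methoxyphenyl gave a number 54 percentage points lower from compound 1 to compound 2 (beyond the scatter), and replacing it with 4-cyanophenyl gave a number 39.3 percentage points lower from compound 1 to compound 3 (beyond the scatter); between the two phenyl-bearing compounds, the swap of cyano for methoxy gave only a number 14.7 percentage points higher from compound 2 to compound 3 (beyond the scatter). Among the measured compounds shown here, the two substituted phenyl groups thus land in a similar band well beneath compound 1, and 2-fluorophenyl is a third substituted phenyl group of this kind, with no direct precedent among the measured compounds.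

Compound 4 is therefore expected to stay in the band of compounds 2 and 3, giving an estimated 34% in this assay, with a likely range from 15% to 58%. The expected step is a number 3.6 percentage points lower from compound 3 to compound 4 (within the scatter), which is not anticipated to lie beyond the scatter.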

Compound 4, a percentage reported as inhibition, at one concentration (the size of the read-out at that concentration, not a potency): 86.4%
Compound 4: middle estimate off by 52.4 percentage points, on the low side; measured number above the stated range.
By their numbers in this assay, from the lowest: compound 2; then compound 3; then compounds 1 and 4 (each within the scatter of the next).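

In this assay, 2-fluorophenyl gave a number 48.8 percentage points higher from compound 3 to compound 4 (beyond the scatter) and a number 63.5 percentage points higher from compound 2 to compound 4 (beyond the scatter), which shows that a substituted phenyl group on this ring nitrogen does not necessarily stay in the band of compound 2 and compound 3. Set against pyridin-3-yl, the same group gave a number 9.5 percentage points higher from compound 1 to compound 4 (within the scatter), so an aromatic ring of carbon only can stand at this place without separating from compound 1 in this assay, something neither of the earlier phenyl compounds showed. No evidence is available on why 2-fluorophenyl parts so sharply from 4-cyanophenyl and 4-methoxyphenyl.

On these data alone, compound 4 differs from compound 2 and compound 3 both in the substituent and in where it sits on the phenyl ring, so it remains open whether 4-fluorophenyl would stay with compound 4 or fall back to the band of compound 2 and compound 3, and whether 2-methoxyphenyl, 2-chlorophenyl or plain phenyl would do the same. These readings, each taken at one concentration in one cell line, also leave open how compound 1 and compound 4 compare in potency.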